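Swapping One Halogen on the Shared Core

The source may report more compounds than this note shows. Statements on the series, on what has been measured and on what is new or still open speak of the compounds shown alone.

Compound 1 `CC(C)NC1=NS(=O)(=O)c2cc(Cl)c(Cl)cc2N1` in a functional assay (aorta) with Rattus norvegicus as the target, with a stated time of 90 min, at 37 degrees C; a higher number here means that more compound is needed for the effect, a lower number that less compound is needed: 2300 nM
Compound 2 `CCCCCCNC1=NS(=O)(=O)c2cc(Cl)c(Cl)cc2N1` in this assay: > 300000 nM, a limit of the assay rather than a number

Among the compounds with values here, compound 1 thus holds the only number among the two results. Within the data shown here, the single measured step, an at least 130-fold higher number from compound 1 to compound 2 (2.11 log units; beyond the scatter), concerns the group on the amine nitrogen and does not touch the aromatic ring, so no measured step bears directly on the change now in view. Compound 3 `CC(C)NC1=NS(=O)(=O)c2cc(F)c(Cl)cc2N1` differs from compound 1 by fluoro in place of chloro on an aromatic carbon. Without a measured step at this position, only a modest shift is expected in this assay. Compound 3 is estimated at 4000 nM, with a range from 1500 nM to 12000 nM. This estimate means a 1.7-fold higher number from compound 1 to compound 3 (0.24 log units; within the scatter).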

Compound 3, half-maximal effective concentration: 41500 nM
Compound 3: the middle estimate sits 10-fold (1.02 log units) below what was measured; the whole stated range lies below it.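

The aromatic position ortho to a chloro group turns out to matter in this assay: fluoro in place of chloro gives an 18-fold higher number from compound 1 to compound 3 (1.26 log units; beyond the scatter), a large change from swapping a single heavy atom. So the aromatic ring, and not only the group on the amine nitrogen, shapes the number here. Nothing shown explains why this swap moves the number so far.

As far as these compounds go, whether a bromo group, a methyl group or a plain hydrogen at this position would stay close to compound 1 remains open. So does whether the remaining chloro group is equally sensitive to change.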